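From phenyl to 3,4,5-trimethoxyphenyl in compound 4

The source may report more compounds than this note shows. Statements on the series, on what has been measured and on what is new or still open speak of the compounds shown alone.

In a functional assay on HL-60 cells (Homo sapiens) for antiproliferative activity, read by MTT assay (a lower number here means a stronger inhibitor, a higher number a weaker inhibitor), compound 3 (`O=C(N/N=C/c1ccccc1)c1cn(C2CC2)c2cc(N3CCNCC3)c(F)cc2c1=O`) stands only at a limit, <= 25000 nM and no number. Compound 1 (`O=C(N/N=C/c1ccccc1)c1cn(C2CC2)c2cc(N/N=C/c3ccccc3)c(F)cc2c1=O`) likewise reports only a limit, <= 25000 nM and no number. Compound 2 (`COc1ccc(/C=N/NC(=O)c2cn(C3CC3)c3cc(N/N=C/c4ccc(OC)c(O)c4)c(F)cc3c2=O)cc1O`) also reports only a limit, <= 25000 nM and no number. The whole record is thus (the limit of <= 25000 nM in this assay, at which 3 of the 3 values shown sit). Compound 4 (`COc1cc(/C=N/NC(=O)c2cn(C3CC3)c3cc(N4CCNCC4)c(F)cc3c2=O)cc(OC)c1OC`) carries 3,4,5-trimethoxyphenyl in place of phenyl on a carbon with a double bond to nitrogen. Among the compounds with values here, the only measured step is a step that the two limits leave unreadable from compound 1 to compound 3 and it swaps a different group, so it offers no size to carry over. The expected change is loose, a step that the limit leaves unreadable from compound 3 to compound 4 in this assay and leaning only weakly towards stronger inhibition. Compound 4 is estimated at 10000 nM (range 2500 nM to 25000 nM).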

Compound 4, half-maximal inhibitory concentration: <= 25000 nM
Compound 4: only a limit was reported; the forecaster's own chance of this, stated with the estimate: 45%; the middle value is on the limit's open side.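

In this assay compound 4 gives <= 25000 nM, a limit and not a number. No step can be read between compound 3 and compound 4. The compounds shown leave open how strongly each one inhibits: the limit of <= 25000 nM in this assay, at which 4 of the 4 values shown sit.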